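The source may report more compounds than this note shows. Statements on the series, on what has been measured and on what is new or still open speak of the compounds shown alone.

Measured in a functional assay on the whole organism with Rattus norvegicus as the target; a higher number here means that more compound is needed for the effect, a lower number that less compound is needed:
compound 1 `COc1ccc(Cl)cc1C(=O)NCCN(C)Cc1ccccc1`: 3 mg/kg
compound 2 `CCNS(=O)(=O)c1ccc(OC)c(C(=O)NCCN(C)Cc2ccccc2)c1`: > 30 mg/kg

Compound 2 gives > 30 mg/kg, which is a limit of the assay and not a number. Going by the values given here, for the series so far, that is the limit of > 30 mg/kg in this assay, at which 1 of the 2 values shown sits.

Compound 3 `COc1ccc(S(C)(=O)=O)cc1C(=O)NCCN(C)Cc1ccccc1` departs from compound 2 on a sulfonyl sulfur whose other neighbour is an aromatic carbon: methyl in place of ethylamino on a sulfonyl sulfur. In words, methyl stands in place of ethylamino, so that ethylsulfamoyl becomes methylsulfonyl.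

Among the compounds with values here, only one measured step bears on this change: an at least 10-fold higher number from compound 1 to compound 2 (1.00 log units; beyond the scatter), with ethylsulfamoyl in place of chloro. Within the data shown here, that step brought in the group now being altered, but no measured step alters the group itself, so it offers only a loose guide. It does leave room for a lower number in this assay once ethylsulfamoyl is gone, and a partial return towards compound 1 is expected. The expected change is an at least 2.5-fold lower number from compound 2 to compound 3 (0.39 log units; beyond the scatter). For compound 3 the estimated value is 12 mg/kg, with an expected range of 3 mg/kg to 50 mg/kg.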

Compound 3, dose for half-maximal effect: 3 mg/kg
The estimate for compound 3 lay 4.0-fold (0.60 log units) above the measured number, within the range that was stated.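

In this assay, the step from ethylsulfamoyl to methylsulfonyl on this sulfonyl sulfur gives an at least 10-fold lower number from compound 2 to compound 3 (1.00 log units; beyond the scatter), so the high number of the ethylsulfamoyl compound does not extend to every sulfonyl group at this place; it goes with the ethylamino part. The replacement of chloro by methylsulfonyl on an aromatic carbon gives no change at the digits printed from compound 1 to compound 3 (within the scatter), so in this series a sulfonyl group at this place is compatible with the number carried by the chloro compound. The value of compound 2 is a limit of the assay and not a number: the limit of > 30 mg/kg in this assay, at which 1 of the 3 values shown sits.

The change from ethylamino to methyl alters both the size of the substituent and the presence of the nitrogen with its hydrogen, and the compounds shown do not separate these two differences. Ethylsulfonyl, which keeps the ethyl without the nitrogen, and dimethylsulfamoyl, which keeps the nitrogen without its hydrogen, would tell them apart, while the parent sulfamoyl would show whether the ethyl matters at all.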